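Swapping the Aryl Group on the Sulfonyl Sulfur

The source may report more compounds than this note shows. Statements on the series, on what has been measured and on what is new or still open speak of the compounds shown alone.

Compound 3 `Nc1cc(S(=O)(=O)c2cccc(Cl)c2)c([N+](=O)[O-])c2cccnc12` belongs to a small set of compounds that share one core and differ only in the group on the sulfonyl sulfur. Among the measured compounds shown here, in an assay for binding affinity to Neuropeptide Y receptor type 1 (Homo sapiens), read by radioligand binding (a higher number here means a weaker inhibitor, a lower number a stronger inhibitor), compound 3 gives 892 nM, the lower of the two numbers known, though its gap to compound 2 is within the scatter. Compound 2 `Nc1cc(S(=O)(=O)c2ccc(Cl)cc2)c([N+](=O)[O-])c2cccnc12` gives 1750 nM in this assay, and a 2.0-fold lower number from compound 2 to compound 3 (0.29 log units; within the scatter). Compound 1 `CS(=O)(=O)c1cc(N)c2ncccc2c1[N+](=O)[O-]` reaches only a limit of the assay, > 10000 nM. Compound 1 thus sits at the limit of > 10000 nM in this assay, at which 1 of the 3 values shown sits. Trading the methyl for an aryl group made a clear difference: an at least 5.7-fold lower number from compound 1 to compound 2 (0.75 log units; beyond the scatter) and an at least 11-fold lower number from compound 1 to compound 3 (1.04 log units; beyond the scatter).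

Compound 4 `CCc1ccccc1S(=O)(=O)c1cc(N)c2ncccc2c1[N+](=O)[O-]` has not yet been measured. It differs from compound 3 in one place: 2-ethylphenyl in place of 3-chlorophenyl on a sulfonyl sulfur. For the measured compounds named here, the only measured step that exchanges one aryl group for another is a 2.0-fold lower number from compound 2 to compound 3 (0.29 log units; within the scatter), which stayed within the scatter, so a step near the scatter is expected here, with some room for a weaker number as the 2-ethylphenyl is untested. In this assay compound 4 is expected to give 1300 nM, between 400 nM and 4500 nM. That estimate amounts to an expected 1.5-fold higher number from compound 3 to compound 4 (0.16 log units; within the scatter).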

Compound 4, inhibition constant: 129 nM
Compound 4: the middle estimate sits 10-fold (1.00 log units) above what was measured; measured number outside the range, below it.
By their numbers in this assay, from the lowest: compound 4; then compounds 3 and 2 (each within the scatter of the next). At a limit, above all of these: compound 1.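

In this assay the choice of aryl group on the sulfonyl sulfur matters in its own right: the change to 2-ethylphenyl gives a 6.9-fold lower number from compound 3 to compound 4 (0.84 log units; beyond the scatter) and a 14-fold lower number from compound 2 to compound 4 (1.13 log units; beyond the scatter) while the swap between the two chlorophenyl groups stayed within the scatter. Having an aryl group in place of the methyl therefore does not account for the whole gain. Against the methyl, the change gives an at least 77-fold lower number from compound 1 to compound 4 (1.88 log units; beyond the scatter) and that step is only a bound, since compound 1 stands at a limit: (the limit of > 10000 nM in this assay, at which 1 of the 4 values shown sits).

With a single ethyl compound, the shown data cannot separate the contribution of the ethyl group from that of losing the chlorine. Also open, going by these compounds, is how a longer chain such as propyl in place of the ethyl, or an amine or carboxylic acid on the aryl ring, would fare.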